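This account rests on a few compounds, and the source may have more. Where it says the series, first, only, none or still open, it means among the compounds named here.

In a functional assay on K562 cells (Homo sapiens) for antiproliferative activity, read by MTT assay, with a stated time of 48 h (a higher number here means a weaker inhibitor, a lower number a stronger inhibitor), compound 1 `CCCn1c(N)c(-c2nc3ccccc3[nH]2)c2nc(C#N)c(C#N)nc21` gives > 50000 nM as a limit and not a number. Compound 2 `N#Cc1nc2c(-c3nc4ccccc4[nH]3)c(N)n(CCO)c2nc1C#N` gives > 50000 nM as a limit too. Compound 3 `CCCCn1c(N)c(-c2nc3ccccc3[nH]2)c2nc(C#N)c(C#N)nc21` also gives > 50000 nM as a limit, so it has no true number to start from. The whole set offers only the limit of > 50000 nM in this assay, at which 3 of the 3 values shown sit, and nothing stronger. Compound 4 `N#Cc1nc2c(-c3nc4ccccc4[nH]3)c(N)n(CCCN3CCCCC3)c2nc1C#N` differs from compound 3 by piperidin-1-yl in place of methyl on a saturated chain carbon, three bonds along the chain from an aromatic nitrogen and so turns butyl into 3-(piperidin-1-yl)propyl. The earlier changes on this chain are a step that the two limits leave unreadable from compound 1 to compound 3 and a step that the two limits leave unreadable from compound 2 to compound 3 and a step that the two limits leave unreadable from compound 1 to compound 2 and none of them gives a size to carry over. Any readable change in this assay can only be towards a stronger inhibitor, and a modest one is expected. The expected move is an at least 3.3-fold lower number from compound 3 to compound 4 (0.52 log units; beyond the scatter) and it remains uncertain. For compound 4 the estimated value is 15000 nM with an expected range from 3000 nM to 50000 nM and another limit remains quite possible.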

Compound 4, half-maximal inhibitory concentration: 3460 nM
For compound 4 the middle estimate is 4.3-fold (0.64 log units) above the measured one, within the range that was stated.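

The earlier steps on this chain cannot be read in this assay, because those compounds all sit at one limit: the limit of > 50000 nM in this assay, at which 3 of the 4 values shown sit.

Piperidin-1-yl on the saturated chain carbon, three bonds along the chain from an aromatic nitrogen, gives the first readable change, an at least 14-fold lower number from compound 3 to compound 4 (1.15 log units; beyond the scatter), and the other two comparisons give an at least 14-fold lower number from compound 2 to compound 4 (1.15 log units; beyond the scatter) and an at least 14-fold lower number from compound 1 to compound 4 (1.15 log units; beyond the scatter). This position can therefore carry a change that registers in this read-out.

As far as these compounds go, whether the step depends on the whole ring or only on its nitrogen remains open, and so does the length of the chain. A dimethylamino or morpholin-4-yl group at the chain end, or a 2-(piperidin-1-yl)ethyl chain, would help separate these.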